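This account rests on a few compounds, and the source may have more. Where it says the series, first, only, none or still open, it means among the compounds named here.

Two compounds have been measured so far in an assay on cells for inhibition of HSP60/HSP10 (Homo sapiens), with a stated time of 60 min; a lower number here means a stronger inhibitor, a higher number a weaker inhibitor:

Compound 1, `O=S(=O)(Nc1ccc(-c2nc3ccccc3o2)cc1)c1ccc(Cl)s1`, gives 31000 nM.
Compound 2, `O=S(=O)(Nc1ccc2oc(-c3ccccc3)nc2c1)c1cccc(F)c1`, gives only > 100000 nM, which is a limit of this assay rather than a number.

Compound 2 thus stands at the weak end of what has been seen: the limit of > 100000 nM in this assay, at which 1 of the 2 values shown sits. Compound 1 carries a different core, and its value shows measurable though weak inhibition. Compound 3, `O=S(=O)(Nc1ccc2oc(-c3ccccc3)nc2c1)c1ccc(Cl)c(Cl)c1`, keeps the core of compound 2 and alters only the group on the sulfonyl sulfur: 3,4-dichlorophenyl in place of 3-fluorophenyl on a sulfonyl sulfur. No measured step joins any two of these compounds, so the size of this change in this assay cannot be read from the data. In this assay the expected step is an at least 1.4-fold lower number from compound 2 to compound 3 (0.15 log units; that floor lies within the scatter), a modest move towards stronger inhibition that may well turn out to be none beyond the scatter. Compound 3 is therefore estimated at 70000 nM, in a range from 20000 nM to 200000 nM, with a fair chance that only a limit is reported.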

Compound 3, half-maximal inhibitory concentration: > 100000 nM
Compound 3: no number, only a limit (the forecaster's own chance of this, stated with the estimate: 55%); at least 1.4-fold (0.15 log units) between middle value and limit.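

Going by these compounds alone, compound 2 and compound 3 both give only a limit rather than a number, so no step between them can be read. The compounds shown leave open whether 3,4-dichlorophenyl in place of 3-fluorophenyl on a sulfonyl sulfur changes inhibition at all.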